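Halogen swap on the hydrazone aryl ring and cytotoxicity

The source may report more compounds than this note shows. Statements on the series, on what has been measured and on what is new or still open speak of the compounds shown alone.

Of the compounds shown here, three of a shared core have been tested in an ADME assay on L6 cells (Rattus norvegicus) for cytotoxicity, read by resazurin assay, with a stated time of 72 h; on this read-out higher numbers stand for weaker inhibition and lower numbers for stronger inhibition. Compound 1 `N/C(CC(O)c1cccc2ccccc12)=N\N=C\c1ccc(Cl)c(Cl)c1` gives 16000 nM in this assay, the lowest of the three numbers. Compound 3 `N/C(CC(O)c1cccc2ccccc12)=N\N=C\c1ccc(C(F)(F)F)cc1` gives 26000 nM, a number that sits within the scatter of that of compound 1, so no order between them can be drawn. Compound 2 `N/C(CC(O)c1ccc2ccccc2c1)=N\N=C\c1ccc(Cl)c(Cl)c1` gives 100000 nM, a number clearly higher than that of compound 1 and beyond the scatter. Within the data shown here, none of these three pairs differs in a single place only, so no single-point step between measured compounds is available.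

Compound 4 `N/C(CC(O)c1cccc2ccccc12)=N\N=C\c1cccc(Br)c1` has not yet been measured in this assay. It differs from compound 1 in one place: 3-bromophenyl in place of 3,4-dichlorophenyl on a carbon with a double bond to nitrogen. Among the measured compounds shown here, the data give no step of this kind among the measured compounds, so the expectation rests on the narrow span in which compound 1 and compound 3 lie. The step of a 1.6-fold higher number from compound 1 to compound 4 (0.19 log units; within the scatter) is expected to be small, if anything toward a slightly higher number, and may well stay within the scatter. Compound 4 is therefore estimated at 25000 nM in this assay, with a range from 9000 nM to 80000 nM.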

Compound 4, half-maximal inhibitory concentration: 3900 nM
Estimate against measurement, compound 4: 6.4-fold (0.81 log units) above, and the stated range ends above it.
By their numbers in this assay, from the lowest: compound 4; then compounds 1 and 3 (each within the scatter of the next); then compound 2.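

Among these compounds, replacing 3,4-dichlorophenyl with 3-bromophenyl on a carbon with a double bond to nitrogen gives, in this assay, a 4.1-fold lower number from compound 1 to compound 4 (0.61 log units; beyond the scatter) and provides the first single-place step in this set, showing that the aryl group at this place can move the read-out beyond the scatter, here toward stronger inhibition. The two groups share the same six-membered aromatic ring of carbon only, have no hydrogen-bond donors or acceptors and carry no net charge, so these computed features do not separate them; they differ in their halogen substituents, chlorine in one and bromine in the other, and in where these stand. No measurement shown here gives a reason for the step.

Going by these compounds, it remains open whether the halogen itself or its placement on the ring accounts for the step, which a 3-chlorophenyl or a 4-bromophenyl group at this place could help to separate. On these data alone, it is also open whether the same change would have a similar effect on the core of compound 2, and how a phenyl ring bearing an amine or a carboxylic acid would read in this assay at this place.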